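Propanoyloxy in place of fluoro: notes on the series

The source may hold more compounds than are shown below. What is called first, only, known or untested is meant among the compounds shown, and "the series" means these compounds.

compound 1 `C[S+]([O-])/C=C/c1cc(=O)c2ccccc2o1` gives 1900 nM
compound 2 `C[S+]([O-])/C=C/c1cc(=O)c2cc(F)ccc2o1` gives 2100 nM
compound 3 `CCC(=O)Oc1ccc2oc(/C=C/[S+](C)[O-])cc(=O)c2c1` is not yet measured

In a functional assay on A549 cells (Homo sapiens) for cytotoxicity, with a stated time of 48 h (on this read-out lower numbers stand for stronger inhibition and higher numbers for weaker inhibition), compound 2 gives 2100 nM and stands within the scatter of compound 1. Among the measured compounds shown here, compound 3 carries propanoyloxy in place of fluoro on an aromatic carbon and no measured compound holds that group. For the measured compounds named here, the one measured step, a 1.1-fold higher number from compound 1 to compound 2 (0.04 log units; within the scatter) for fluoro in place of hydrogen on an aromatic carbon, lies within the scatter. It is thin evidence, so no step beyond the scatter is expected in this assay and the range stays wide. The expected step is a 1.1-fold lower number from compound 2 to compound 3 (0.02 log units; within the scatter) and no direction is favoured. For compound 3 the estimate is 2000 nM with an expected range from 750 nM to 5000 nM and this remains an estimate only.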

Compound 3, half-maximal inhibitory concentration: 2400 nM
Compound 3: the middle estimate sits 1.2-fold (0.08 log units) below what was measured; the measured number falls inside the stated range.
By their numbers in this assay, from the lowest: compounds 1, 2 and 3 (each within the scatter of the next).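

In this assay, the aromatic carbon takes propanoyloxy, with 5 heavy atoms and 2 hydrogen-bond acceptors, in place of the lone fluorine, and this gives a 1.1-fold higher number from compound 2 to compound 3 (0.06 log units; within the scatter). Set against the hydrogen of compound 1, the same group gives a 1.3-fold higher number from compound 1 to compound 3 (0.10 log units; within the scatter), so across compounds 1, 2 and 3 neither a small nor a larger ester group at this place moves the number beyond the scatter. No evidence on hand bears on this result.

Still open, as far as these compounds go, is whether an amine, a carboxylic acid or a longer ester chain at this place would give a step beyond the scatter.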